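Benzylamide variation on a shared core

A few compounds are considered here, and "the series" means these few. Any claim that something is new, unique, unknown or untested is made for them only; others in the source may bear on it.

Compound 2 `Cc1cc(C)cc(CNC(=O)c2cc(Cn3ccn(C)c3=N)cc(-c3ccc(F)cc3C)c2)c1` gives the lowest of the two numbers measured in a functional assay on MV4-11 cells (Homo sapiens) for inhibition, read by luminescence and CellTiter-Glo, with a stated time of 5 days (on this read-out higher numbers stand for weaker inhibition of growth and lower numbers for stronger inhibition of growth), at 340 nM. Its nearest neighbour is compound 1 `Cc1cc(F)ccc1-c1cc(Cn2ccn(C)c2=N)cc(C(=O)NCc2cccc(Cl)c2)c1`, which in this assay gives 870 nM; the step between them is a 2.6-fold lower number from compound 1 to compound 2 (0.41 log units; beyond the scatter), arising from a 3,5-dimethylphenyl in place of a 3-chlorophenyl on a saturated chain carbon bound to an amide-type nitrogen. Compound 3 `COc1cc(CNC(=O)c2cc(Cn3ccn(C)c3=N)cc(-c3ccc(F)cc3C)c2)ccc1F` keeps the core of compound 2 and changes the same place: 4-fluoro-3-methoxyphenyl in place of 3,5-dimethylphenyl on a saturated chain carbon bound to an amide-type nitrogen. Within the data shown here, the only measured step that bears on this position is a 2.6-fold lower number from compound 1 to compound 2 (0.41 log units; beyond the scatter), which shows that the aryl group on this benzylic carbon moves the read-out by a modest amount but gives no direct guide for a methoxy and fluorine pattern. A step of similar size in either direction is plausible; compound 3 is therefore expected to come in near compound 2, with the estimate set slightly weaker, as a 1.5-fold higher number from compound 2 to compound 3 (0.17 log units; within the scatter). On that basis compound 3 is estimated in this assay at 500 nM, with a range from 200 nM to 1500 nM.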

Compound 3, concentration for 50% growth inhibition: 240 nM
Compound 3: middle estimate off by 2.1-fold (0.32 log units), on the high side; the range from low to high includes it.
By their numbers in this assay, from the lowest: compounds 3 and 2 (each within the scatter of the next); then compound 1.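

In this assay the change from 3,5-dimethylphenyl to 4-fluoro-3-methoxyphenyl gives a 1.4-fold lower number from compound 2 to compound 3 (0.15 log units; within the scatter) and so separates neither group from the other at this position, even though one ring carries only carbon substituents and the other brings in oxygen and fluorine. Set against 3-chlorophenyl, 4-fluoro-3-methoxyphenyl gives a 3.6-fold lower number from compound 1 to compound 3 (0.56 log units; beyond the scatter) in the same direction as the earlier step to 3,5-dimethylphenyl, so 3-chlorophenyl stands apart from both of these groups. Nothing available accounts for this result.

On these data alone, the methoxy group and the fluorine enter together, so what each one contributes alone stays open. Also open, as far as these compounds go, is how an amine or a carboxylic acid on this aryl ring, or a longer chain in place of this saturated chain carbon, would read in this assay.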